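Oxetanyl in Place of Pyridylmethyl on a Ring Nitrogen

The compounds below may be only part of what the source reports. "The series", "measured", "known", "first", "only" and "open" are said of these compounds alone.

Of the compounds shown here, two have been measured so far. Compound 1 `CN(C[C@H]1Cc2c(cccc2N2CCN(Cc3ccccn3)CC2)CN1)[C@H]1CCCc2cccnc21` gives 4.47 nM in a functional assay on CCRF-CEM cells for antagonist activity at C-X-C chemokine receptor type 4 (Homo sapiens), read by calcium flux, with stated times of 25 min and 90 s (on this read-out higher numbers stand for weaker inhibition and lower numbers for stronger inhibition), the lower of the two numbers. Compound 2 `Cc1cnc2c(c1)CCC[C@@H]2N(C)C[C@H]1Cc2c(cccc2N2CCNCC2)CN1` gives 16.1 nM in this assay, a number beyond the scatter above that of compound 1, and nothing more than these two values is known of that pair. Compound 3 `CN(C[C@H]1Cc2c(cccc2N2CCN(C3COC3)CC2)CN1)[C@H]1CCCc2cccnc21` has not yet been measured in this assay. It differs from compound 1 by oxetan-3-yl in place of (pyridin-2-yl)methyl on an amine nitrogen in a ring. Going by the values given here, since no step between measured compounds that differ in a single place is available, the expectation rests on the value of compound 1 alone and on the nature of the change. The step from compound 1 to compound 3 is expected to be a modest weakening, a 2.2-fold higher number from compound 1 to compound 3 (0.35 log units; beyond the scatter), roughly at the edge of the scatter. Compound 3 is therefore estimated at 10 nM in this assay, with a range from 3 nM to 35 nM.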

Compound 3, half-maximal inhibitory concentration: 381 nM
Estimate against measurement, compound 3: 38-fold (1.58 log units) below; the whole stated range lies below it.
By their numbers in this assay, from the lowest: compound 1; then compound 2; then compound 3.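

In this assay, the substituent on this amine nitrogen of the six-membered ring with 2 nitrogen proves far from interchangeable: oxetan-3-yl in place of (pyridin-2-yl)methyl brings an 85-fold higher number from compound 1 to compound 3 (1.93 log units; beyond the scatter), a large step. The change replaces 7 heavy atoms and a six-membered aromatic ring with 4 heavy atoms and a four-membered non-aromatic ring, while each group counts 1 hydrogen-bond acceptor, so that count does not follow the step. No measurement is at hand that explains the step.

The compounds shown leave open whether the step follows the aromatic ring, its ring nitrogen or the number of heavy atoms, a question that benzyl, with carbon in place of that nitrogen, or cyclohexylmethyl on the same nitrogen would help to separate. Going by these compounds, the step is also read on a single background, so its size with other groups elsewhere on the core remains open.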